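Shortening the amine chain on a shared benzotriazine dioxide core

The source may hold more compounds than are shown below. What is called first, only, known or untested is meant among the compounds shown, and "the series" means these compounds.

Measured compounds:
compound 1 `[O-][n+]1nc(NC2CCCCC2)[n+]([O-])c2ccccc21` gives 2500 nM
compound 2 `CCCCCCCCNc1n[n+]([O-])c2ccccc2[n+]1[O-]` gives 7200 nM
compound 3 `O=[N+]([O-])c1ccc(CNc2n[n+]([O-])c3ccccc3[n+]2[O-])cc1` gives 1400 nM

Of the compounds shown here, three have been tested in a functional assay on HL-60 cells (Homo sapiens) for cytotoxicity, read by MTT assay, with a stated time of 48 h (a higher number here means a weaker inhibitor, a lower number a stronger inhibitor), all sharing one core and differing only in the group on the amine nitrogen. Compound 2 stands at the highest number of the three: compound 1 lies at a lower number, beyond the scatter, and compound 3 lies lower still, also beyond the scatter. The unmeasured compound 4 `CCNc1n[n+]([O-])c2ccccc2[n+]1[O-]` is reached from compound 2 by the change (hydrogen in place of hexyl on a saturated chain carbon, two bonds along the chain from a nitrogen on an aromatic ring), which cuts the chain on the amine down while leaving the core untouched. Among the measured compounds shown here, no measured pair reports this kind of shortening, so the size of the step is open. Compound 1 and compound 3, each carrying a more compact group than compound 2, sit at lower numbers, which hints that a shorter chain may also move toward a lower number, though nothing in hand secures that. The step of a 1.8-fold lower number from compound 2 to compound 4 (0.26 log units; within the scatter) is therefore expected to be moderate, toward a lower number, but within a wide band. Compound 4 is estimated at 4000 nM, in the range 1500 nM to 12000 nM.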

Compound 4, half-maximal inhibitory concentration: 9000 nM
Beside the measured number, compound 4's estimate is 2.3-fold (0.35 log units) below it; the range from low to high includes it.
By their numbers in this assay, from the lowest: compounds 3 and 1 (each within the scatter of the next); then compounds 2 and 4 (each within the scatter of the next).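

Within this assay, taking hexyl off the chain of compound 2 gives a 1.3-fold higher number from compound 2 to compound 4 (0.10 log units; within the scatter), so at this position the cut does not separate the two compounds, and chain length across this span has no readable effect. The comparison with the ring-bearing amine is clearer: ethyl in place of cyclohexyl on the nitrogen gives a 3.6-fold higher number from compound 1 to compound 4 (0.56 log units; beyond the scatter), a modest step that places compound 4 apart from compound 1. Nothing available explains either step.

On these data alone, what remains open is whether a butyl chain would fall in the same band as compound 2 and compound 4, or whether the flat response holds only at these two chain lengths. As far as these compounds go, it is equally open whether a terminal amine or hydroxyl on the ethyl chain, or a cyclopentyl ring on the nitrogen, would shift the number.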